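The source may report more compounds than this note shows. Statements on the series, on what has been measured and on what is new or still open speak of the compounds shown alone.

In a functional assay on Cortical neurone cells (Mus musculus, strain C57BL/6), read by FLIPR and calcium flux, with a stated time of 8 min (a lower number here means a stronger inhibitor, a higher number a weaker inhibitor), compound 1 `Cc1ccc(Cc2nc3[nH]c(Cc4ccccc4)cc(=O)n3n2)cc1` gives 2470 nM, and compound 2 `Cc1ccc(Cc2nc3[nH]c(-c4ccccc4)cc(=O)n3n2)cc1` gives 1150 nM, the lower of the two numbers. Compound 3 `Cc1ccc(-c2nc3[nH]c(-c4ccccc4)cc(=O)n3n2)cc1` changes compound 2 as follows: 4-methylphenyl in place of 4-methylbenzyl on an aromatic carbon. This puts 4-methylphenyl in place of 4-methylbenzyl on an aromatic carbon between two ring nitrogen atoms. Among the compounds with values here, the only measured step, a 2.1-fold lower number from compound 1 to compound 2 (0.33 log units; beyond the scatter), is modest and puts phenyl in place of benzyl elsewhere on the shared core, so a change of like size toward a lower number is expected in this assay. The expected step is a 1.6-fold lower number from compound 2 to compound 3 (0.22 log units; within the scatter). Compound 3 is estimated at 700 nM, within a range of 250 nM to 2000 nM.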

Compound 3, half-maximal inhibitory concentration: 3210 nM
Estimate against measurement, compound 3: 4.6-fold (0.66 log units) below; measured number outside the range, above it.
By their numbers in this assay, from the lowest: compound 2; then compounds 1 and 3 (each within the scatter of the next).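

In this assay, 4-methylphenyl in place of 4-methylbenzyl on the aromatic carbon between two ring nitrogen atoms brings a 2.8-fold higher number from compound 2 to compound 3 (0.45 log units; beyond the scatter) and so runs opposite to the earlier swap elsewhere on the shared core, which brought a 2.1-fold lower number from compound 1 to compound 2 (0.33 log units; beyond the scatter). The same kind of change therefore does not carry from one place to the other, and at this place the 4-methylbenzyl compound has the lower number. Nothing available explains this reversal. The compounds shown leave open how a longer chain, such as 2-phenylethyl, or an amine would behave at this place.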